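The compounds below may be only part of what the source reports. "The series", "measured", "known", "first", "only" and "open" are said of these compounds alone.

Working notes on the dihydropyridine series.

Compound 1 `CCOC(=O)C1=C(C)NC(C)=C(C(=O)OC)C1c1cnc(SC)n1Nc1ccccc1` gives 1.66 nM in an assay on isolated protein (strain albino) for antagonist activity at Voltage-dependent L-type calcium channel subunit alpha-1C (Cavia porcellus); on this read-out lower numbers stand for stronger inhibition and higher numbers for weaker inhibition. Compound 2 `COC(=O)C1=C(C)NC(C)=C(C(=O)OC(C)C)C1c1cnc(SC)n1Nc1ccccc1` gives 6.35 nM in this assay, and compound 3 `COCCOC(=O)C1=C(C)NC(C)=C(C(=O)OC)C1c1cnc(SC)n1Nc1ccccc1` gives 9.65 nM. Compound 3 thus has the highest of the three numbers; its nearest neighbour is compound 2, and the step of a 1.5-fold higher number from compound 2 to compound 3 (0.18 log units; within the scatter) lies within the scatter, while the step of a 5.8-fold higher number from compound 1 to compound 3 (0.76 log units; beyond the scatter) is beyond it. The step of a 3.8-fold higher number from compound 1 to compound 2 (0.58 log units; beyond the scatter) points the same way: either enlargement of the methyl ester raises the number by a modest amount.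

Compound 4 `COC(=O)C1=C(C)NC(C)=C(C(=O)OCc2ccccc2)C1c1cnc(SC)n1Nc1ccccc1` differs from compound 3 in one place: phenyl in place of methoxymethyl on a saturated chain carbon bound to an oxygen next to a carbonyl group. Going by the values given here, no measured pair shows this exact exchange. The bearing steps are those on the same ester chain, from compound 1 to compound 2 and from compound 1 to compound 3, which both raise the number modestly, and from compound 2 to compound 3, which stays within the scatter. A benzyl ester is another enlargement at the same position, so the expectation is a small further rise or no step beyond the scatter, with the estimated step of a 1.2-fold higher number from compound 3 to compound 4 (0.09 log units; within the scatter). Compound 4 is estimated at 12 nM in this assay, within the range 4 nM to 40 nM.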

Compound 4, half-maximal inhibitory concentration: 2.21 nM
Compound 4: the middle estimate sits 5.4-fold (0.73 log units) above what was measured; the whole stated range lies above it.
By their numbers in this assay, from the lowest: compounds 1 and 4 (each within the scatter of the next); then compounds 2 and 3 (each within the scatter of the next).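

In this assay, a larger group on the ester chain does not by itself raise the number: benzyl on an oxygen next to a carbonyl group gives a 4.4-fold lower number from compound 3 to compound 4 (0.64 log units; beyond the scatter) and a 2.9-fold lower number from compound 2 to compound 4 (0.46 log units; beyond the scatter), both beyond the scatter, while a 1.3-fold higher number from compound 1 to compound 4 (0.12 log units; within the scatter) stays within it. The rise seen with the isopropyl and 2-methoxyethyl esters therefore does not follow the size of the group across the compounds shown, and compound 4 goes against any such trend, since phenyl brings 6 heavy atoms where methoxymethyl brings 3, yet the number falls. No measurement at hand accounts for this difference between the benzyl ester and the other two enlarged esters.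

From the compounds shown here alone, what remains open is whether the lower number depends on the aromatic ring itself, which cyclohexylmethyl on the same oxygen would test, and how a longer chain such as 2-phenylethyl would behave. An ester chain ending in an amine, such as 2-(dimethylamino)ethyl, or a benzyl group carrying chlorine or methoxy on its phenyl ring, also lies outside what these compounds can show.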